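A few compounds are considered here, and "the series" means these few. Any claim that something is new, unique, unknown or untested is made for them only; others in the source may bear on it.

Series notes in an ADME assay on PC-3 cells (Homo sapiens) for cytotoxicity, read by WST assay, tested at 100 uM; a lower number here means less inhibition, a higher number more inhibition at the concentration tested (going by the name of the read-out):
compound 1 `CC(C)(C)OC(=O)c1cccc(NC(=O)C2CCCN(C(=O)c3cc(C(F)(F)F)cc(C(F)(F)F)c3)C2)c1` gives 0%;
compound 2 `O=C(Nc1cccc(CN2CCCC2)c1)C1CCCN(C(=O)c2cc(C(F)(F)F)cc(C(F)(F)F)c2)C1` gives 51%;
compound 3 `O=C(c1ccccc1)c1cccc(NC(=O)C2CCCN(C(=O)c3cc(C(F)(F)F)cc(C(F)(F)F)c3)C2)c1` gives 0%.

Compound 2 stands highest of the three numbers, with the values of compound 1 and compound 3 both lying beyond the scatter below it. The unmeasured compound 4 `O=C(Nc1ccc(Cl)nc1)C1CCCN(C(=O)c2cc(C(F)(F)F)cc(C(F)(F)F)c2)C1` differs from compound 2 by 6-chloropyridin-3-yl in place of 3-((pyrrolidin-1-yl)methyl)phenyl on an amide-type nitrogen. Among the compounds with values here, the steps that bear on this are the two that add or remove the (pyrrolidin-1-yl)methyl group: a number 51 percentage points higher from compound 1 to compound 2 (beyond the scatter) and a number 51 percentage points lower from compound 2 to compound 3 (beyond the scatter), each a large step. Compound 4 likewise gives up the (pyrrolidin-1-yl)methyl group, so a large fall in this assay is expected, a number 46 percentage points lower from compound 2 to compound 4 (beyond the scatter). For compound 4 the estimate is 5%, with a range from 0% to 25%.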

Compound 4, a percentage reported as inhibition, at one concentration (the size of the read-out at that concentration, not a potency): 25%
Beside the measured number, compound 4's estimate is 20 percentage points below it; the measured number falls inside the stated range.
By their numbers in this assay, from the lowest: compounds 1 and 3 (each within the scatter of the next); then compound 4; then compound 2.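

In this assay, 6-chloropyridin-3-yl in place of 3-((pyrrolidin-1-yl)methyl)phenyl gives a number 26 percentage points lower from compound 2 to compound 4 (beyond the scatter). Loss of the (pyrrolidin-1-yl)methyl group therefore does not by itself take the number to zero: compound 4 gives 25%, while compound 1 gives 0% and compound 3 gives 0%. Nothing available accounts for the read-out that remains with compound 4.

The compounds shown do not separate the contribution of the chlorine from that of the ring nitrogen in compound 4. From the compounds shown here alone, it also remains open how an unsubstituted pyridin-3-yl or a phenyl carrying a dimethylaminomethyl group would compare.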